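Hydroxy-naphthoquinone ether amides: antiproliferative series notes

This account rests on a few compounds, and the source may have more. Where it says the series, first, only, none or still open, it means among the compounds named here.

Measured compounds:
compound 1 `O=C(O)CCCCCNC(=O)COC1=CC(=O)c2c(O)cccc2C1=O` — "not determined" (no result reported)
compound 2 `CC(C)(C)OC(=O)NCCCCC(CNC(=O)COC1=CC(=O)c2c(O)cccc2C1=O)NC(=O)OC(C)(C)C` — 3100 nM
compound 3 `CC(C)(C)OC(=O)NCC(CCCCNC(=O)COC1=CC(=O)c2c(O)cccc2C1=O)CNC(=O)CCCCC1SCC2NC(=O)NC21` — "not determined" (no result reported)

The shared core carries an oxyacetamide linker to a varied chain. Going by the values given here, in a functional assay on COLO 205 cells (Homo sapiens) for antiproliferative activity (on this read-out higher numbers stand for weaker inhibition and lower numbers for stronger inhibition), compound 2 gives 3100 nM, the only number reported; in this assay compound 1 gives "not determined" (no result reported) and compound 3 gives "not determined" (no result reported), so compound 2 stands alone and no step between measured compounds can be drawn.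

Compound 4 `CC(C)(C)OC(=O)NCCCCCCNC(=O)COC1=CC(=O)c2c(O)cccc2C1=O` is not yet measured. It differs from compound 2 by hydrogen in place of (tert-butoxycarbonyl)amino on a saturated chain carbon bound to two saturated chain carbons. The change removes one (tert-butoxycarbonyl)amino group from the chain while leaving the core, the linker and the other (tert-butoxycarbonyl)amino untouched.

Among the compounds with values here, with no measured step to lean on, the expected change from compound 2 is small, and the estimated step of a 1.2-fold lower number from compound 2 to compound 4 (0.09 log units; within the scatter) is taken to lie within the scatter of repeated measurements. Compound 4 is expected to give about 2500 nM in this assay, with a range from 800 nM to 8000 nM.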

Compound 4, half-maximal inhibitory concentration: 1300 nM
Compound 4: middle estimate off by 1.9-fold (0.28 log units), on the high side; the range from low to high includes it.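

Going by these compounds alone, the only readable step, in this assay, comes from hydrogen in place of (tert-butoxycarbonyl)amino on a saturated chain carbon bound to two saturated chain carbons (a 2.4-fold lower number from compound 2 to compound 4 (0.38 log units; beyond the scatter)). This modest step lies beyond the scatter and goes towards stronger inhibition, so the antiproliferative read-out does not depend on the (tert-butoxycarbonyl)amino at this position. The earlier compounds could not show this, since compound 2 stood alone with a number, and no evidence at hand explains the step.

Still open, as far as these compounds go, is whether the remaining (tert-butoxycarbonyl)amino matters at all, and whether a free amine or a carboxylic acid in its place would keep the number. A longer chain is equally untested by the compounds shown, so the single step says nothing yet about chain length.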